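Trifluoromethyl for Methyl, Carried Over to the Sulfone

The source may report more compounds than this note shows. Statements on the series, on what has been measured and on what is new or still open speak of the compounds shown alone.

Three compounds have been measured in a functional assay on MT4 cells (Homo sapiens) for cytotoxicity; on this read-out lower numbers stand for stronger inhibition and higher numbers for weaker inhibition:

compound 1, `COc1cc(C)cc(Sc2cccc(N)c2C#N)c1`, gives 10000 nM
compound 2, `COc1cc(Sc2cccc(N)c2C#N)cc(C(F)(F)F)c1`, gives 9000 nM
compound 3, `COc1cc(C)cc(S(=O)(=O)c2cccc(N)c2C#N)c1`, gives 94000 nM

Compound 2 differs from compound 1 by one change:
trifluoromethyl in place of methyl on an aromatic carbon
This change made a 1.1-fold lower number from compound 1 to compound 2 (0.05 log units; within the scatter). Compound 3 stands on a different core; how its core differs from that of compound 1 is not broken down here. In this assay compound 3 gives the highest of the three numbers, and its step from compound 1 lies beyond the scatter.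

Compound 4, `COc1cc(C(F)(F)F)cc(S(=O)(=O)c2cccc(N)c2C#N)c1`, has not yet been measured. It differs from compound 3 by
trifluoromethyl in place of methyl on an aromatic carbon
The place is described in the same words for both pairs, so this is the same change as from compound 1 to compound 2. The step from compound 3 to compound 4 is therefore expected to be about as small, a 1.1-fold lower number from compound 3 to compound 4 (0.04 log units; within the scatter), because the earlier step was a 1.1-fold lower number from compound 1 to compound 2 (0.05 log units; within the scatter). Compound 4 is expected to give roughly 85000 nM, between 40000 nM and 180000 nM.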

Compound 4, half-maximal inhibitory concentration: 164000 nM
Estimate against measurement, compound 4: 1.9-fold (0.29 log units) below; the measured number falls inside the stated range.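

On the core of compound 3, trifluoromethyl in place of methyl gives a 1.7-fold higher number from compound 3 to compound 4 (0.24 log units; within the scatter) in this assay. Set beside the earlier step, the change is small on both cores, and the two steps cannot be told apart: the same change on two cores in this assay, a 1.1-fold lower number (0.05 log units; within the scatter) from compound 1 to compound 2 and a 1.7-fold higher number (0.24 log units; within the scatter) from compound 3 to compound 4, 1.9-fold (0.29 log units) apart, within the scatter of two such steps. This shows that the change carried over between these two cores in this assay, but two pairs do not make a rule for other cores, other places on the ring or other read-outs.

The compounds shown leave open whether an amine, a carboxylic acid or a longer chain in the same place would give a larger step. They also leave open whether such a group would behave alike on both cores.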